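Changing the Aryl Group Next to the Ring Nitrogen

A few compounds are considered here, and "the series" means these few. Any claim that something is new, unique, unknown or untested is made for them only; others in the source may bear on it.

Of the compounds shown here, two have so far been measured in a functional assay on NCI/ADR-RES cells (Homo sapiens) for inhibition, read by sulforhodamine B assay, with a stated time of 48 h, tested at 10 uM; a higher number here means more inhibition at the concentration tested (going by the name of the read-out), a lower number less inhibition. Compound 1 `Fc1ccccc1-c1cn2ccnc2c(-c2ccc3ncn(C4CCCCC4)c3c2)n1` gives 4.51% in this assay. Compound 2 `CCc1ccc(-c2cn3ccnc3c(-c3ccc4ncn(Cc5ccccc5)c4c3)n2)cc1` gives 41.2% in this assay, the higher of the two numbers, and its distance from compound 1 lies beyond the usual scatter of repeated measurements. Because compound 1 and compound 2 differ at more than one place, the two values alone do not tell which part of the structure carries that difference.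

Compound 3 `Cc1cccc(-c2cn3ccnc3c(-c3ccc4ncn(Cc5ccccc5)c4c3)n2)c1` has not yet been measured. It differs from compound 2 in one place: 3-methylphenyl in place of 4-ethylphenyl on an aromatic carbon. Among the compounds with values here, no pair of measured compounds shows the effect of such a change, so the size of the step from compound 2 to compound 3 can only be guessed. Compound 3 is expected to give about 35% in this assay, within a range from 15% to 55%. The expected step of a number 6.2 percentage points lower from compound 2 to compound 3 (within the scatter) is estimated to be small, not beyond the scatter, with the value of compound 2 41.2% as its starting point.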

Compound 3, a percentage reported as inhibition, at one concentration (the size of the read-out at that concentration, not a potency): 12.1%
Compound 3: the middle estimate sits 22.9 percentage points above what was measured; measured number below the stated range.
By their numbers in this assay, from the lowest: compounds 1 and 3 (each within the scatter of the next); then compound 2.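

This position on the shared core does not treat its aryl groups alike: in this assay, 3-methylphenyl in place of 4-ethylphenyl gives a number 29.1 percentage points lower from compound 2 to compound 3 (beyond the scatter). The step lies beyond the scatter, although the two groups share one six-membered aromatic ring of carbon only, with 0 hydrogen-bond donors, 0 hydrogen-bond acceptors and no net charge. A change confined to the small alkyl group on that ring is therefore enough to remove a large part of the inhibition seen at the concentration tested, and nothing at hand explains the size of this step.

On these data alone, what stays open is whether the step follows the length of the alkyl group or its place on the ring, a question that 4-methylphenyl and 3-ethylphenyl groups would separate. As far as these compounds go, it is also open how this position responds to a longer chain such as propyl, or to an amine or a carboxylic acid on the same ring.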